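A few compounds are considered here, and "the series" means these few. Any claim that something is new, unique, unknown or untested is made for them only; others in the source may bear on it.

Measured so far:
compound 1, `CCCCCCCCOc1ccc2c(Cl)ccnc2c1`: 3240 nM
compound 2, `Clc1ccnc2cc(OCc3ccccc3)ccc12`: 2720 nM

Both numbers come from a functional assay on NCI-H1650 cells (Homo sapiens) for cytotoxicity, read by MTT assay, with a stated time of 48 h; a lower number here means a stronger inhibitor, a higher number a weaker inhibitor. Compound 2 has the lower of the two, but its gap to compound 1 lies within the scatter, so the two stand level. Compound 3, `CCOc1ccc2c(Cl)ccnc2c1`, is not yet measured. It differs from compound 2 by methyl in place of phenyl on a saturated chain carbon bound to an oxygen on an aromatic ring. Within the data shown here, no measured pair shows this change, so its size is not known from the data here; both measured compounds carry a larger group at this place than compound 3, and the step is expected to be a modest loss, a 2.0-fold higher number from compound 2 to compound 3 (0.31 log units; beyond the scatter). For compound 3 the estimate is 5500 nM, range 2200 nM to 15000 nM.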

Compound 3, half-maximal inhibitory concentration: 3340 nM
Compound 3: middle estimate off by 1.6-fold (0.22 log units), on the high side; the range from low to high includes it.
By their numbers in this assay, from the lowest: compounds 2, 1 and 3 (each within the scatter of the next).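

In this assay, methyl in place of phenyl gives a 1.2-fold higher number from compound 2 to compound 3 (0.09 log units; within the scatter), and hydrogen in place of hexyl on the saturated chain carbon, two bonds along the chain from an oxygen on an aromatic ring, gives a 1.0-fold higher number from compound 1 to compound 3 (0.01 log units; within the scatter). Compound 1, compound 2 and compound 3 therefore stand level, and neither the phenyl nor the hexyl shows a measurable gain over the smaller group of compound 3. No supporting evidence bears on this flat result. As far as these compounds go, whether an amine or a carboxylic acid on this chain would depart from this level remains open.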